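The source may hold more compounds than are shown below. What is called first, only, known or untested is meant among the compounds shown, and "the series" means these compounds.

Measured so far in an in vitro functional assay on cells for agonist activity at Bombesin receptor subtype-3 (Homo sapiens), read by luminescence and calcium flux; a higher number here means that more compound is needed for the effect, a lower number that less compound is needed:
- compound 1 `O=C(O)c1ccccc1-c1ccc(CCc2ncc(CC3CCOCC3)[nH]2)cc1` gives 338 nM
- compound 2 `O=C(O)c1ccccc1-c1ccc(CCc2ncc(Cc3cccc(Cl)c3)[nH]2)cc1` gives 825 nM
- compound 3 `CC(C)(C)CCc1cnc(CCc2ccc(-c3ccccc3C(=O)O)cc2)[nH]1` gives 39 nM

Compound 1 stands second highest of the three numbers; its nearest neighbour is compound 2, at a 2.4-fold higher number from compound 1 to compound 2 (0.39 log units; beyond the scatter), and the furthest is compound 3, at an 8.7-fold lower number from compound 1 to compound 3 (0.94 log units; beyond the scatter). Compound 4 `Cc1ccccc1Cc1cnc(CCc2ccc(-c3ccccc3C(=O)O)cc2)[nH]1` is not yet measured. It differs from compound 1 in one place: 2-methylphenyl in place of oxan-4-yl on a saturated chain carbon bound to an aromatic carbon. Going by the values given here, the closest analogue among the measured steps is the one to compound 2, an aromatic ring entering in place of oxan-4-yl on a saturated chain carbon bound to an aromatic carbon, which read a 2.4-fold higher number from compound 1 to compound 2 (0.39 log units; beyond the scatter). The neopentyl step, a 21-fold lower number from compound 2 to compound 3 (1.33 log units; beyond the scatter), runs the other way, and nothing here separates one aromatic ring from another. A modest rise in this assay is therefore expected, a 1.9-fold higher number from compound 1 to compound 4 (0.28 log units; within the scatter). Compound 4 is estimated at 650 nM, range 250 nM to 1600 nM.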

Compound 4, half-maximal effective concentration: 127 nM
For compound 4 the middle estimate is 5.1-fold (0.71 log units) above the measured one; the measured number lies below the stated range.
By their numbers in this assay, from the lowest: compound 3; then compound 4; then compound 1; then compound 2.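

With 2-methylphenyl in place of oxan-4-yl, an aromatic ring at this place gives a 2.7-fold lower number from compound 1 to compound 4 (0.43 log units; beyond the scatter), opposite in direction to the step to compound 2. The aromatic rings are now separated, with 2-methylphenyl in place of 3-chlorophenyl giving a 6.5-fold lower number from compound 2 to compound 4 (0.81 log units; beyond the scatter). Neopentyl still holds the lowest number, with 2-methylphenyl in its place giving a 3.3-fold higher number from compound 3 to compound 4 (0.51 log units; beyond the scatter).

Nothing measured here gives a reason for these differences. Left open is whether the gap between the two aromatic rings follows the methyl or the chlorine, which an unsubstituted phenyl would address, and whether a longer branched alkyl chain lowers the number further.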